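Moving the Thiophene Attachment Point on a Shared Core

The source may report more compounds than this note shows. Statements on the series, on what has been measured and on what is new or still open speak of the compounds shown alone.

Of the compounds shown here, three built around one shared core have been tested in an ADME assay on HEL cells (Homo sapiens) for cytotoxicity, with a stated time of 3 days; on this read-out higher numbers stand for lower toxicity in this test and lower numbers for higher toxicity in this test. Compound 1 `Cc1cc(-c2ccc(O)cc2)c2ncc(CSCCc3ccccc3)n2c1` gives 20 ug/mL. Compound 2 `Cc1cc(-c2cccs2)cn2c(CSCCc3ccccc3)cnc12` gives 20 ug/mL, which is level with compound 1 at the digits printed and so within the scatter of this assay. Compound 3 `Cc1cc(I)c2ncc(CSCCc3ccccc3)n2c1` gives >= 4 ug/mL, and this is a limit of the assay rather than a number. The change from compound 1 to compound 3 puts iodo in place of 4-hydroxyphenyl on an aromatic carbon, but a step that the limit leaves unreadable from compound 1 to compound 3 cannot be read in size, since (the limit of >= 4 ug/mL in this assay, at which 1 of the 3 values shown sits).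

Compound 4 `Cc1cc(-c2ccsc2)cn2c(CSCCc3ccccc3)cnc12` has not yet been measured. It differs from compound 2 in one place: thiophen-3-yl in place of thiophen-2-yl on an aromatic carbon. For the measured compounds named here, none of the measured steps moves a thiophene attachment point, and the only measured step is unreadable, so there is nothing in these numbers that points to a change in either direction. The expectation is therefore that compound 4 stays close to compound 2, with no change at the digits printed from compound 2 to compound 4 (within the scatter) expected to lie within the scatter. Compound 4 is estimated to give 20 ug/mL, between 8 ug/mL and 50 ug/mL.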

Compound 4, minimum cytotoxic concentration: >= 4 ug/mL
Compound 4: a limit, no number; the forecaster's own chance of this, stated with the estimate: 25%; the middle value lies beyond the limit too.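

Compound 4 gives >= 4 ug/mL, which is a limit of the assay and not a number. The step from compound 2 to compound 4 therefore cannot be read in size: the limit of >= 4 ug/mL in this assay, at which 2 of the 4 values shown sit.

The compounds shown leave open whether thiophen-3-yl in place of thiophen-2-yl changes the cytotoxicity read-out at all.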